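Working notes: one added methoxy on compound 3

A few compounds are considered here, and "the series" means these few. Any claim that something is new, unique, unknown or untested is made for them only; others in the source may bear on it.

Measured in a functional assay on HCT-116 cells (Homo sapiens) for cytotoxicity, read by scintillation counting and thymidine incorporation, with a stated time of 72 h; a higher number here means a weaker inhibitor, a lower number a stronger inhibitor:
- compound 1 `C#CC=C(c1cc(OC)cc(OC)c1)c1ccc(OC)c(OC)c1` gives > 10000 nM as a limit of the assay
- compound 2 `COc1cc(OC)cc(C(=CC#N)c2ccc(OC)c(N)c2)c1` gives 1.4 nM
- compound 3 `COc1cc(OC)cc(C(=CC#N)c2ccc(OC)c(OC)c2)c1` gives 18 nM

Of the two values that are true numbers, compound 3 has the higher one, and compound 2 is its nearest neighbour, with a 13-fold higher number from compound 2 to compound 3 (1.11 log units; beyond the scatter) in the series. The value of compound 1 is only a limit.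

Compound 4 `COc1ccc(C(=CC#N)c2cc(OC)c(OC)c(OC)c2)cc1OC` differs from compound 3 by methoxy in place of hydrogen on an aromatic carbon in the form of methoxy in place of hydrogen on an aromatic carbon, ortho to two methoxy groups and para to a large group. Two measured steps give indirect guidance: an at least 550-fold lower number from compound 1 to compound 3 (2.74 log units; beyond the scatter) and a 13-fold higher number from compound 2 to compound 3 (1.11 log units; beyond the scatter) are both large, but both lie at other places. Among the measured compounds shown here, neither tests this position, so they show only that single changes can matter strongly, and a large step cannot be ruled out. A modest move towards a lower number is expected, possibly not beyond the scatter. The expected step is a 2.3-fold lower number from compound 3 to compound 4 (0.35 log units; beyond the scatter) in this assay, with wide uncertainty. For compound 4 the estimate is 8 nM, with an expected range of 1.5 nM to 60 nM in this assay.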

Compound 4, half-maximal inhibitory concentration: 41 nM
Beside the measured number, compound 4's estimate is 5.1-fold (0.71 log units) below it; the range from low to high includes it.
By their numbers in this assay, from the lowest: compound 2; then compound 3; then compound 4. At a limit, above all of these: compound 1.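

In this assay, methoxy in place of hydrogen on the aromatic carbon ortho to two methoxy groups and para to a large group gives a 2.3-fold higher number from compound 3 to compound 4 (0.36 log units; beyond the scatter). Among the compounds shown here, this is the first reading at this position, since the earlier steps lay at other places: the added methoxy moves the series towards a weaker inhibitor, but only modestly, and compound 4 remains a nanomolar-range inhibitor in this assay. Nothing among the data shown accounts for this step.

Going by these compounds, it remains open whether the step is specific to methoxy, or whether a fluorine, a hydroxy group or an ethoxy group at this position would give a similar result. Also open, on these data alone, is whether the added methoxy would have a step of similar size on the amino-bearing compound 2.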